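Aryl variation on the shared core: working notes toward compound 4

The compounds below may be only part of what the source reports. "The series", "measured", "known", "first", "only" and "open" are said of these compounds alone.

Three compounds share one core and differ only in the aryl group on the carbon with a double bond to nitrogen. Compound 1 `Cc1ccccc1/C(CCN1CCN(c2ccccn2)CC1)=N\O` gives 72% in a functional assay on HEK293 cells with D(4) dopamine receptor (Homo sapiens) as the target, read by FLIPR; a lower number here means a smaller maximal response, a higher number a larger maximal response. Compound 2 `O/N=C(\CCN1CCN(c2ccccn2)CC1)c1cccc(Cl)c1` gives 73% in this assay, and compound 3 `O/N=C(/CCN1CCN(c2ccccn2)CC1)c1cc(F)cc(F)c1` gives 70%. Compound 2 thus holds the largest of the three numbers, but compound 1 and compound 3 both sit within the scatter of it.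

Within the data shown here, the one measured step at this position, a number 2 percentage points lower from compound 1 to compound 3 (within the scatter), shows that exchanging one aryl group for another leaves the maximal response unchanged within the scatter.

Compound 4 `Cc1ccc(O)c(/C(CCN2CCN(c3ccccn3)CC2)=N/O)c1` is not yet measured. Its change from compound 2 is 2-hydroxy-5-methylphenyl in place of 3-chlorophenyl on a carbon with a double bond to nitrogen. Among the measured compounds shown here, the step from compound 1 to compound 3 is the only guide, and it was flat, so no step beyond the scatter is expected in this assay; the entering group brings a hydrogen-bond donor and acceptor that no measured compound carries, so the range is kept wide. Compound 4 is estimated at 70%, between 56% and 82%, which means an expected step of a number 3 percentage points lower from compound 2 to compound 4 (within the scatter).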

Compound 4, largest response reached (reported as efficacy), in percent of the reference or control that the assay uses: 73%
Beside the measured number, compound 4's estimate is 3 percentage points below it, within the range that was stated.
By their numbers in this assay, from the lowest: compounds 3, 1, 2 and 4 (each within the scatter of the next).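

In this assay, 2-hydroxy-5-methylphenyl in place of 3-chlorophenyl gives no change at the digits printed from compound 2 to compound 4 (within the scatter). The entering group carries 1 hydrogen-bond donor and 1 hydrogen-bond acceptor, which the aryl groups of compound 1, compound 2 and compound 3 lack, so the flat picture on the carbon with a double bond to nitrogen now extends to an aryl group with both features. Nothing at hand explains why the maximal response stays within the scatter across this exchange.

Going by these compounds, all four groups at this position are substituted phenyl rings, so the outcome with a cyclohexyl group, or with a phenyl ring bearing an amine or a carboxylic acid, stays open. Also open, on these data alone, is whether the response stays this flat with a longer chain in place of the saturated chain on the shared core.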